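Removing a Bromine from a Chalcone Antiproliferative

This account rests on a few compounds, and the source may have more. Where it says the series, first, only, none or still open, it means among the compounds named here.

The measurements here come from a functional assay on MGC-803 cells (Homo sapiens) for antiproliferative activity, read by MTT assay, with a stated time of 72 h; a higher number here means a weaker inhibitor, a lower number a stronger inhibitor. Compound 1 `O=C(COc1ccc(C(=O)/C=C/c2cccc(Br)c2)cc1)N[C@H]1CCOC1=O` gives 11900 nM in this assay. Compound 2 `O=C1OCC[C@@H]1NC(=S)SCCOc1ccccc1[N+](=O)[O-]`, built on a different linker, gives 47000 nM in this assay. Compound 3 `O=C(CNc1ccc(F)cc1)N[C@H]1CCOC1=O` yields only a limit of the assay, > 64000 nM, and no number. That limit, (the limit of > 64000 nM in this assay, at which 1 of the 3 values shown sits), marks the ceiling of what this assay reports.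

Among the two real numbers, compound 1 stands lowest, and the gap to compound 2 lies beyond the usual scatter of repeated measurements, so compound 1 is the stronger inhibitor of the two.

Compound 4 `O=C(COc1ccc(C(=O)/C=C/c2ccccc2)cc1)N[C@H]1CCOC1=O` has not yet been measured in this assay. It differs from compound 1 in one place: hydrogen in place of bromo on an aromatic carbon. No pair of measured compounds differing in one place is available, so the size of this step cannot be read off from the data shown. Compound 4 is expected to sit close to compound 1, perhaps slightly weaker, with the step staying within the scatter. Compound 4 is expected to give about 17000 nM in this assay, with a likely range from 6000 nM to 50000 nM. The expected step of a 1.4-fold higher number from compound 1 to compound 4 (0.15 log units; within the scatter) is estimated to be modest.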

Compound 4, half-maximal inhibitory concentration: > 64000 nM
Compound 4: a limit, no number (the forecaster's own chance of this, stated with the estimate: 10%); middle value at least 3.7-fold (0.57 log units) from the limit.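

In this assay, compound 4 gives > 64000 nM, which is a limit of the assay and not a number. Swapping the bromo for hydrogen on the aromatic ring, with the rest of the structure unchanged, gives an at least 5.3-fold higher number from compound 1 to compound 4 (0.73 log units; beyond the scatter), the first direct reading of a single change among the compounds shown, and it reveals that the measurable activity of compound 1 is lost when this one atom goes. With this result, compound 4 joins compound 3 at the top of the range the assay can report, so neither of these compounds carries a number: the limit of > 64000 nM in this assay, at which 2 of the 4 values shown sit.

Going by these compounds, since compound 4 has only a limit, the step has a lower bound and its true size remains unknown. This single pair also cannot show whether the effect is specific to bromine, or whether chlorine, fluorine, a methyl group or a methoxy group in the same place on the 3-bromophenyl ring of compound 1 would keep the activity of compound 1 or lose it as hydrogen does.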